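A few compounds are considered here, and "the series" means these few. Any claim that something is new, unique, unknown or untested is made for them only; others in the source may bear on it.

Compound 1, `C=C(C)[C@@H]1CC=C(C)/C(=N/NC(=O)Nc2nnc(-c3ccc(Cl)cc3)o2)C1`: 300 mg/kg
Compound 2, `C=C(C)[C@@H]1CC=C(C)/C(=N/NC(=O)Nc2nnc(-c3ccc(OC)cc3)o2)C1`: 300 mg/kg
Compound 3, `C=C(C)[C@@H]1CC=C(C)/C(=N/NC(=O)Nc2nnc(-c3ccc(F)cc3)o2)C1`: 300 mg/kg

In a functional assay on the whole organism (strain Swiss albino) with Mus musculus as the target, with a stated time of 4 h (on this read-out lower numbers stand for an effect already at smaller amounts and higher numbers for an effect only at larger amounts of compound), compound 3 gives 300 mg/kg and stands level with compounds 1 and 2, the differences lying within the scatter. The three measured steps, no change at the digits printed from compound 1 to compound 2 (within the scatter), no change at the digits printed from compound 1 to compound 3 (within the scatter) and no change at the digits printed from compound 2 to compound 3 (within the scatter), all exchange one group for another on the same aromatic carbon and none of them moves the read-out beyond the scatter. Compound 4, `C=C(C)[C@@H]1CC=C(C)/C(=N/NC(=O)Nc2nnc(-c3cccc(O)c3)o2)C1`, differs from compound 3 by 3-hydroxyphenyl in place of 4-fluorophenyl on an aromatic carbon. Among the compounds with values here, no measured step brings in a hydroxy group, so the bearing of the earlier steps is indirect, but each of them left the read-out unchanged. Compound 4 is therefore expected to show no change at the digits printed from compound 3 to compound 4 (within the scatter), no step beyond the scatter, and its estimated value is 300 mg/kg within 150 mg/kg to 600 mg/kg.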

Compound 4, minimum effective dose: 300 mg/kg
Compound 4: middle estimate and measured number agree at the digits printed; the measured number falls inside the stated range.
By their numbers in this assay, from the lowest: compounds 1, 2, 3 and 4 (each within the scatter of the next).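

Compound 4 puts 3-hydroxyphenyl at this position, the only group shown here with a hydrogen-bond donor, and in this assay the steps read no change at the digits printed from compound 3 to compound 4 (within the scatter) and no change at the digits printed from compound 2 to compound 4 (within the scatter) and no change at the digits printed from compound 1 to compound 4 (within the scatter) for this exchange. The read-out at this carbon of the five-membered aromatic ring therefore stays level when the substituent on the phenyl ring is a hydroxy group at the 3-position rather than a 4-substituent. No evidence is available that explains this level read-out. On these data alone, whether an amine or a carboxylic acid on the phenyl ring would shift the read-out remains open.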